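The compounds below may be only part of what the source reports. "The series", "measured", "known", "first", "only" and "open" are said of these compounds alone.

Measured in an assay on cells for displacement of a labelled ligand from transmembrane domain-containing protein TMIGD3 (Homo sapiens), read by scintillation counting, with a stated time of 120 min, tested at 1 uM; a higher number here means more inhibition at the concentration tested (going by the name of the read-out), a lower number less inhibition:
compound 1, `COc1ccc(-c2cn3ccnc(N)c3n2)cc1`: 1%
compound 2, `Nc1nccn2cc(-c3ccco3)nc12`: 5%
compound 3, `COc1ccc(-c2cn3cc(Br)nc(N)c3n2)cc1`: 24%

Compound 1 and compound 3 share a core and differ by bromo in place of hydrogen on an aromatic carbon; this change produced a number 23 percentage points higher from compound 1 to compound 3 (beyond the scatter). Compound 2 carries a different core, and the difference between the two cores is not broken down here; in this assay compound 2 and compound 1 give numbers within the usual scatter of each other.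

Compound 4, `Nc1nc(Br)cn2cc(-c3ccco3)nc12`, has not yet been measured. It relates to compound 2 by bromo in place of hydrogen on an aromatic carbon, the same change as from compound 1 to compound 3. Because a number 23 percentage points higher from compound 1 to compound 3 (beyond the scatter) was a modest rise beyond the scatter, a step of similar size is expected for compound 4, namely a number 21 percentage points higher from compound 2 to compound 4 (beyond the scatter). Compound 4 is therefore estimated at 26%, likely between 8% and 45%.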

Compound 4, a percentage reported as inhibition, at one concentration (the size of the read-out at that concentration, not a potency): 28%
Compound 4: middle estimate off by 2 percentage points, on the low side; measured number inside the range.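

In this assay bromo in place of hydrogen on an aromatic carbon gave a number 23 percentage points higher from compound 2 to compound 4 (beyond the scatter), and this step matches the one seen on the other core: the same change on two cores in this assay, a number 23 percentage points higher (beyond the scatter) from compound 1 to compound 3 and a number 23 percentage points higher (beyond the scatter) from compound 2 to compound 4, 0 percentage points apart, within the scatter of two such steps. Within these two pairs, the change therefore carried over from the core of compound 1 to the core of compound 2 with its size intact. This does not show that it would carry over to any other core, and these read-outs at one concentration are not potencies.

Among the compounds shown, only hydrogen and bromo occupy this carbon. On these data alone, whether chloro, a methyl group or an amine there would give a step of like size remains open, as does the effect of the bromo change with a longer chain on the amino group.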